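Swapping the oxime ether tail of compound 2

A few compounds are considered here, and "the series" means these few. Any claim that something is new, unique, unknown or untested is made for them only; others in the source may bear on it.

Compound 1 `OC1O[C@H](CO/N=C2\CCc3cc(Sc4cc(F)cc(C5CCOCC5)c4)ccc32)[C@H](O)[C@H](O)[C@H]1O`: in this assay a limit only, > 2500 nM
Compound 2 `C/C(=N\OCCSc1nnc(C)s1)c1ccc(Sc2cc(F)cc(C3CCOCC3)c2)cc1`: 230 nM
Compound 3 `C/C(=N\O)c1ccccc1Sc1cc(F)cc(C2CCOCC2)c1`: in this assay a limit only, > 10000 nM

For the measured compounds named here, in a functional assay (blood) for inhibition, with Homo sapiens as the target (a higher number here means a weaker inhibitor, a lower number a stronger inhibitor), compound 2 gives 230 nM, the only actual number among the three. Compound 1 sits at a limit, namely (the limit of > 2500 nM in this assay, at which 1 of the 3 values shown sits). Compound 3 likewise sits at a limit, (the limit of > 10000 nM in this assay, at which 1 of the 3 values shown sits). Compound 4 `CCOC(=O)c1csc(CO/N=C(\C)c2ccc(Sc3cc(F)cc(C4CCOCC4)c3)cc2)n1` is not yet measured. It keeps the shared core of compound 2 and differs only in the oxime ether tail: 4-(ethoxycarbonyl)-1,3-thiazol-2-yl in place of ((5-methyl-1,3,4-thiadiazol-2-yl)sulfanyl)methyl on a saturated chain carbon bound to an oxygen. Going by the values given here, no measured step covers a change of this kind, so the size of the step is open. Compound 4 is expected to stay close to compound 2, with a step of a 1.7-fold higher number from compound 2 to compound 4 (0.24 log units; within the scatter) that need not exceed the scatter. Compound 4 is therefore estimated at 400 nM, within 100 nM to 2000 nM.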

Compound 4, half-maximal inhibitory concentration: 150 nM
Compound 4: the middle estimate sits 2.7-fold (0.43 log units) above what was measured, within the range that was stated.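

In this assay, putting 4-(ethoxycarbonyl)-1,3-thiazol-2-yl in place of ((5-methyl-1,3,4-thiadiazol-2-yl)sulfanyl)methyl on a saturated chain carbon bound to an oxygen gives a 1.5-fold lower number from compound 2 to compound 4 (0.19 log units; within the scatter) and so shows that this position takes two different tails, each carrying a five-membered aromatic ring, without a step beyond the scatter. No measurement shown accounts for this step. The compounds shown leave open whether an amine or a carboxylic acid in place of the ethoxycarbonyl group would stay as close to compound 2, and whether a longer chain would.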